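This account rests on a few compounds, and the source may have more. Where it says the series, first, only, none or still open, it means among the compounds named here.

Compound 1, `CS(=O)(=O)c1ccc(-c2cnc3[nH]cc(-c4nnc(-c5ccncc5)o4)c(=O)c3c2)cc1`, gives 12.1% in a functional assay on A549 cells (Homo sapiens) for inhibition, read by MTT assay, with a stated time of 24 h, tested at 10 uM; on this read-out lower numbers stand for less inhibition of growth and higher numbers for more inhibition of growth at the one concentration tested.
Compound 2, `CS(=O)(=O)c1ccc(-c2cnc3[nH]cc(-c4nnc(-c5ccc(Cl)cc5)o4)c(=O)c3c2)cc1`, gives 26.8% in this assay.

Among the measured compounds shown here, of the two measured compounds, compound 2 stands highest in this assay, with compound 1 as its only neighbour; the step of a number 14.7 percentage points higher from compound 1 to compound 2 (beyond the scatter) lies beyond the scatter and is modest in size. Compound 3, `N#Cc1ccc(-c2cnc3[nH]cc(-c4nnc(-c5ccc(Cl)cc5)o4)c(=O)c3c2)cc1`, has not yet been measured. It differs from compound 2 in one place: cyano in place of methylsulfonyl on an aromatic carbon. The shared core and the 4-chlorophenyl group are kept unchanged. For the measured compounds named here, no measured step touches this position; the only measured step, from compound 1 to compound 2, changes the group at the other end of the core and therefore says nothing direct about the exchange of methylsulfonyl for cyano. The data thus give no ground for expecting a step in either direction beyond the scatter, and the expected step of a number 1.8 percentage points lower from compound 2 to compound 3 (within the scatter) is accordingly set close to zero, with a wide allowance for the unknown. Compound 3 is estimated to give 25% in this assay, between 5% and 50%.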

Compound 3, percent growth inhibition at one concentration: 12.5%
The estimate for compound 3 lay 12.5 percentage points above the measured number; the range from low to high includes it.
By their numbers in this assay, from the lowest: compounds 1 and 3 (each within the scatter of the next); then compound 2.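

The position carrying the methylsulfonyl group is not indifferent in this assay: with the shared core and the 4-chlorophenyl group held fixed, the change from 4-(methylsulfonyl)phenyl to 4-cyanophenyl gives a number 14.3 percentage points lower from compound 2 to compound 3 (beyond the scatter), a modest step. Among the compounds shown here, the earlier step lay at the other end of the core, so this is the first reading at this position, and it shows that of these two groups, methylsulfonyl goes with the higher growth inhibition at the one concentration tested. Nothing at hand speaks to the reason for this difference.

The compounds shown cover only these two groups at this position, so it stays open whether a sulfonamide, an amine, a carboxylic acid or a methoxy group there would stand nearer to compound 2 or to compound 3. Going by these compounds, it also stays open whether the same exchange would give a step of like size with pyridin-4-yl in place of the 4-chlorophenyl group, and how these compounds would behave at other concentrations.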